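This account rests on a few compounds, and the source may have more. Where it says the series, first, only, none or still open, it means among the compounds named here.

Measured in a functional assay on HepG2 cells (Homo sapiens) for antiproliferative activity, read by MTT assay, with a stated time of 72 h; a higher number here means a weaker inhibitor, a lower number a stronger inhibitor:
- Compound 1 `CN1CCC(NC(=O)c2ccc(Cn3nc(-c4cnn(C)c4)c4ccccc4c3=O)cc2)CC1`: 47300 nM
- Compound 2 `Cc1noc(C)c1-c1nn(Cc2ccc(C(=O)NC3CCN(C)CC3)cc2)c(=O)c2ccccc12`: > 100000 nM
- Compound 3 `Cn1cc(-c2nn(Cc3ccc(C(=O)NC4CC(C)(C)N([O])C(C)(C)C4)cc3)c(=O)c3ccccc23)cn1`: 27400 nM

Compound 2 has no number here, only (the limit of > 100000 nM in this assay, at which 1 of the 3 values shown sits). Compound 4 `Cc1noc(C)c1-c1nn(Cc2ccc(C(=O)NC3CCCCC3)cc2)c(=O)c2ccccc12` differs from it by cyclohexyl in place of 1-methylpiperidin-4-yl on an amide-type nitrogen.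

For the measured compounds named here, two measured steps bear on this. Going by the values given here, the only measured change on that nitrogen is a 1.7-fold lower number from compound 1 to compound 3 (0.24 log units; within the scatter), although it involves a different entering group and compounds carrying 1-methyl-1H-pyrazol-4-yl. The other is an at least 2.1-fold higher number from compound 1 to compound 2 (0.32 log units; beyond the scatter), which introduces the 3,5-dimethyl-1,2-oxazol-4-yl group that compound 4 retains. Among the compounds with values here, with a 1.7-fold lower number from compound 1 to compound 3 (0.24 log units; within the scatter) as the only guide at this place, no step beyond the scatter is expected in this assay, and no direction can be firmly assigned.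

The estimated step is an at least 1.2-fold lower number from compound 2 to compound 4 (0.09 log units; that floor lies within the scatter). The expected value for compound 4 is 80000 nM, with an estimated range of 25000 nM to 150000 nM. A result reported only as a limit remains quite possible.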

Compound 4, half-maximal inhibitory concentration: > 100000 nM
Compound 4: a limit, no number (the forecaster's own chance of this, stated with the estimate: 40%); middle value at least 1.2-fold (0.09 log units) away from the limit.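

No step can be read from compound 2 to compound 4 in this assay, because both compounds sit at a limit of the assay, not at a number: the limit of > 100000 nM in this assay, at which 2 of the 4 values shown sit.

The compounds shown leave open how cyclohexyl and 1-methylpiperidin-4-yl on the amide-type nitrogen compare when 3,5-dimethyl-1,2-oxazol-4-yl is present.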